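Dimethylamino placement on the benzyl group of compound 2

A few compounds are considered here, and "the series" means these few. Any claim that something is new, unique, unknown or untested is made for them only; others in the source may bear on it.

Compound 1 `CCN(CCCCCCn1sc2cc(OC)c(OC)cc2c1=O)Cc1ccccc1` and compound 2 `CCN(CCCCCCn1sc2cc(OC)c(OC)cc2c1=O)Cc1ccccc1N(C)C` share the same core and differ only in the dimethylamino group on the aromatic ring. In an assay on isolated protein for inhibition of Amine oxidase [flavin-containing] B (Homo sapiens), read by fluorescence, with a stated time of 30 min (on this read-out lower numbers stand for stronger inhibition and higher numbers for weaker inhibition), compound 1 gives 20100 nM, and in this assay compound 2 gives 19600 nM. The step of a 1.0-fold lower number from compound 1 to compound 2 (0.01 log units; within the scatter) shows that attaching the dimethylamino group where it sits in compound 2 leaves the read-out unchanged within the scatter; on the two numbers available, compound 2 sits within the scatter of compound 1.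

Compound 3 `CCN(CCCCCCn1sc2cc(OC)c(OC)cc2c1=O)Cc1ccc(N(C)C)cc1` has not yet been measured. The change from compound 2 is 4-(dimethylamino)phenyl in place of 2-(dimethylamino)phenyl on a saturated chain carbon bound to an amine nitrogen; the two compounds contain the same atoms joined differently. Going by the values given here, the only measured step that bears on it is a 1.0-fold lower number from compound 1 to compound 2 (0.01 log units; within the scatter), which is flat, and it concerns adding the group rather than moving it. Among the compounds with values here, there is no measured pair that shows what moving the dimethylamino group does. Within the data shown here, with the one relevant step within the scatter, the step of a 1.1-fold lower number from compound 2 to compound 3 (0.04 log units; within the scatter) is expected to stay within the scatter as well. Compound 3 is therefore estimated at 18000 nM, with a range of 7000 nM to 45000 nM.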

Compound 3, half-maximal inhibitory concentration: 12400 nM
Beside the measured number, compound 3's estimate is 1.5-fold (0.16 log units) above it, within the range that was stated.
By their numbers in this assay, from the lowest: compounds 3, 2 and 1 (each within the scatter of the next).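

Working notes on the dimethylamino position. In this assay the pair of compound 2 and compound 3 gives a measured move of the group rather than its addition: 4-(dimethylamino)phenyl in place of 2-(dimethylamino)phenyl, on a saturated chain carbon bound to an amine nitrogen, gives a 1.6-fold lower number from compound 2 to compound 3 (0.20 log units; within the scatter) and so does not separate the two placements on this read-out. Set against the hydrogen of compound 1, the 4-(dimethylamino)benzyl compound gives a 1.6-fold lower number from compound 1 to compound 3 (0.21 log units; within the scatter) and so, like the 2-(dimethylamino)benzyl compound, it cannot be told apart from the compound without the group, which leaves both placements flat on this benzyl ring. No accompanying data speak to what lies behind these values.

Still open, on these data alone, is whether a carboxylic acid or a methoxy group in place of dimethylamino on this ring would take the number beyond the scatter. Also open, as far as these compounds go, is whether a methyl or an isopropyl group in place of the ethyl group on the amine nitrogen would change the read-out for the series.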